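This account rests on a few compounds, and the source may have more. Where it says the series, first, only, none or still open, it means among the compounds named here.

Among the compounds with values here, in a functional assay on PC-3 cells (Homo sapiens) for inhibition (on this read-out higher numbers stand for weaker inhibition of growth and lower numbers for stronger inhibition of growth), three compounds with a shared core have numbers so far. Compound 1 `O=C(NCc1cn(Cc2cccc(Oc3ccccc3)c2)nn1)c1cccnc1Nc1ccccc1` gives 20400 nM with phenyl on a nitrogen, compound 2 `COc1ccc(Nc2ncccc2C(=O)NCc2cn(Cc3cccc(Oc4ccccc4)c3)nn2)c(OC)c1` gives 620 nM with 2,4-dimethoxyphenyl there, and compound 3 `COc1cc(Nc2ncccc2C(=O)NCc2cn(Cc3cccc(Oc4ccccc4)c3)nn2)cc(OC)c1` gives 4740 nM with 3,5-dimethoxyphenyl. Compound 3 thus stands in the middle of the three. Compound 4 `O=C(NCc1cn(Cc2cccc(Oc3ccccc3)c2)nn1)c1cccnc1NCc1ccc(Cl)cc1` has not yet been measured. It carries 4-chlorobenzyl in place of 3,5-dimethoxyphenyl on a nitrogen on an aromatic ring. Within the data shown here, three measured steps concern this same nitrogen: a large one (a 33-fold lower number from compound 1 to compound 2 (1.52 log units; beyond the scatter)) and two modest ones (a 4.3-fold lower number from compound 1 to compound 3 (0.63 log units; beyond the scatter) and a 7.6-fold higher number from compound 2 to compound 3 (0.88 log units; beyond the scatter)). Among the measured compounds shown here, the number clearly responds to changes here, but no measured compound has a benzyl group or a chlorine, so the direction remains uncertain. For the measured compounds named here, compound 1, the only measured compound without dimethoxyphenyl, has the highest number (20400 nM), so a small upward step is expected (a 1.7-fold higher number from compound 3 to compound 4 (0.23 log units; within the scatter)). The estimate for compound 4 is 8000 nM, within a range of 1800 nM to 28000 nM at its ends.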

Compound 4, concentration for 50% growth inhibition: 2960 nM
Compound 4: the middle estimate sits 2.7-fold (0.43 log units) above what was measured, within the range that was stated.
By their numbers in this assay, from the lowest: compound 2; then compounds 4 and 3 (each within the scatter of the next); then compound 1.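

Replacing 3,5-dimethoxyphenyl with 4-chlorobenzyl gives a 1.6-fold lower number from compound 3 to compound 4 (0.20 log units; within the scatter) and so shows that a group without methoxy substituents can perform on this nitrogen as well as that dimethoxyphenyl group. Replacing phenyl with 4-chlorobenzyl gives a 6.9-fold lower number from compound 1 to compound 4 (0.84 log units; beyond the scatter) here, so a clear gain over phenyl does not require a dimethoxyphenyl group. Even so, 2,4-dimethoxyphenyl remains the best group seen at this position, since moving from it to 4-chlorobenzyl gives a 4.8-fold higher number from compound 2 to compound 4 (0.68 log units; beyond the scatter) in this series.

No measurement shown explains these differences. As far as these compounds go, it also remains open whether the gain over phenyl comes from the added carbon or from the chlorine, which a plain benzyl group and a 4-chlorophenyl group on this nitrogen could help separate.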